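Dichloroacetamide anilide: swapping methyl for nitro

The source may report more compounds than this note shows. Statements on the series, on what has been measured and on what is new or still open speak of the compounds shown alone.

Compound 1 `Cc1ccccc1NC(=O)C(Cl)Cl`: "not determined" (no result reported)
Compound 2 `O=C(Nc1ccccc1Cl)C(Cl)Cl`: 50200 nM

In a functional assay on A549 cells (Homo sapiens) for antiproliferative activity, read by MTT assay, with a stated time of 72 h (on this read-out lower numbers stand for stronger inhibition and higher numbers for weaker inhibition), compound 1 stands at "not determined" (no result reported) and so offers no number to start from. Compound 3 `O=C(Nc1ccccc1[N+](=O)[O-])C(Cl)Cl` has not been measured yet. The structural change is nitro in place of methyl on an aromatic carbon, which puts nitro in place of methyl on an aromatic carbon. With no value for compound 1, the size of this step cannot be read from the data. Among the measured compounds shown here, the only nearby anchor is compound 2 at 50200 nM in this assay, a weak result on this scale. Compound 3 is therefore expected to land close to compound 2, with no shift beyond the usual scatter in either direction. For compound 3 the estimated value is 45000 nM, with an expected range from 18000 nM to 110000 nM as the estimate's limits.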

Compound 3, half-maximal inhibitory concentration: 198000 nM
Compound 3: the middle estimate sits 4.4-fold (0.64 log units) below what was measured; the measured number lies above the stated range.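

In this assay, the comparison that can be read is chloro against nitro at this aromatic carbon, and it gives a 3.9-fold higher number from compound 2 to compound 3 (0.60 log units; beyond the scatter). That step lies beyond the usual scatter, so this place on the shared core is not indifferent to the group it carries, and nitro gives the weaker result of the two. The change from methyl to nitro itself cannot be read, as compound 1 has no number, and nothing at hand accounts for the shift between chloro and nitro.

Where methyl would fall relative to chloro and nitro remains open. So does the outcome with other groups at this carbon, such as an amine, a methoxy group or a carboxylic acid, and whether any of them would bring the number down from the weak range seen with compound 2 and compound 3.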